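This account rests on a few compounds, and the source may have more. Where it says the series, first, only, none or still open, it means among the compounds named here.

Measured compounds:
compound 1, `COc1ccc(/C=N/NC(=S)NC(C)(C)[C@H]2CC=C(C)CC2)cc1`: 8400 nM
compound 2, `CC1=CC[C@H](C(C)(C)NC(=S)N/N=C/c2ccc(F)cc2)CC1`: > 100000 nM

In a functional assay on HT-29 cells (Homo sapiens) for inhibition, read by sulforhodamine B assay, with a stated time of 48 h (a lower number here means a stronger inhibitor of growth, a higher number a weaker inhibitor of growth), compound 1 gives 8400 nM. For compound 2 the reported figure of > 100000 nM is a limit of the assay, not a number. Compound 2 therefore stands at the limit of > 100000 nM in this assay, at which 1 of the 2 values shown sits, the weaker end of the two results shown. Going by the values given here, the single measured step, an at least 11-fold higher number from compound 1 to compound 2 (1.07 log units; beyond the scatter), shows that exchanging one group on the aromatic ring can move the result by a large amount, but it concerns a substituent on the phenyl ring and not the exchange now in question. Compound 3, `CC1=CC[C@H](C(C)(C)NC(=S)N/N=C/c2cccs2)CC1`, differs from compound 2 by thiophen-2-yl in place of 4-fluorophenyl on a carbon with a double bond to nitrogen. Among the compounds with values here, no measured pair shows this exchange, so the direction of the step cannot be read from the data; the one step that exists says only that the aryl portion matters. Compound 2 itself is known only as a limit, which leaves room for compound 3 to fall on either side of it. On balance the estimate for compound 3 is 50000 nM, within 8000 nM to 200000 nM, an expected step of an at least 2.0-fold lower number from compound 2 to compound 3 (0.30 log units; that floor lies within the scatter).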

Compound 3, concentration for 50% growth inhibition: 17800 nM
Estimate against measurement, compound 3: 2.8-fold (0.45 log units) above; the measured number falls inside the stated range.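

Going by these compounds alone, at the carbon with a double bond to nitrogen, thiophen-2-yl in place of 4-fluorophenyl turns a result known only as a limit into a measured one in this assay, with an at least 5.6-fold lower number from compound 2 to compound 3 (0.74 log units; beyond the scatter), so this exchange, which no earlier pair covered, does move the result, and towards stronger growth inhibition. The size of that step is only a floor, since compound 2 is a limit of the assay and not a number: the limit of > 100000 nM in this assay, at which 1 of the 3 values shown sits.

The comparison with the methoxy compound adds a second reading at the same place, thiophen-2-yl in place of 4-methoxyphenyl giving a 2.1-fold higher number from compound 1 to compound 3 (0.33 log units; beyond the scatter), so that among these three compounds the order runs from 4-methoxyphenyl through thiophen-2-yl to 4-fluorophenyl, with compound 1 the strongest inhibitor of growth.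

The compounds shown leave open how other rings at this place, such as furan-2-yl or pyridin-2-yl, would read against thiophen-2-yl. They also leave open whether 4-hydroxyphenyl or 4-methylphenyl would stand nearer to compound 1 or to compound 2.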